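The compounds below may be only part of what the source reports. "The series", "measured", "known", "first", "only" and "open" are said of these compounds alone.

Series notes. Three measured analogues share one core, the same acid-bearing side chain and the same pair of flanking groups, and differ only in the arrangement of the core itself. In a functional assay on HEK293 cells for agonist activity at Free fatty acid receptor 1 (Homo sapiens), read by fluorescence and calcium flux, with a stated time of 1 h (a higher number here means that more compound is needed for the effect, a lower number that less compound is needed), compound 1 `COc1ccc(F)c(-c2cnc(COc3cccc([C@@H](CC(=O)O)C4CC4)c3)cc2C2=CCCC2(C)C)c1` gives 11 nM. Compound 2 `COc1ccc(F)c(-c2ccc(COc3cccc([C@@H](CC(=O)O)C4CC4)c3)nc2C2=CCCC2(C)C)c1` gives 9.4 nM in this assay. Compound 3 `COc1ccc(F)c(-c2ncc(COc3cccc([C@@H](CC(=O)O)C4CC4)c3)nc2C2=CCCC2(C)C)c1` gives 37 nM in this assay, the highest of the three numbers; its gap to compound 1 and its gap to compound 2 both lie beyond the usual scatter, so compound 3 needs more compound for the effect than either of the other two. Among the measured compounds shown here, no single-point step connects the three measured compounds, so their values only show that compound 1 and compound 2 sit below compound 3.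

Compound 4 `COc1ccc(F)c(-c2ncc(COc3cccc([C@@H](CC(=O)O)C4CC4)c3)nc2C=C(C)C)c1` is not yet measured. It differs from compound 3 in one place: 2-methylprop-1-en-1-yl in place of 5,5-dimethylcyclopent-1-en-1-yl on an aromatic carbon. For the measured compounds named here, no measured pair in this set carries this exchange, so there is no step to anchor a direction. The expectation for compound 4 in this assay is a modest rise in the number, with an expected step of a 1.9-fold higher number from compound 3 to compound 4 (0.28 log units; within the scatter) near the edge of the scatter. Compound 4 is estimated at 70 nM, with a range from 20 nM to 250 nM.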

Compound 4, half-maximal effective concentration: 9.4 nM
Compound 4: the middle estimate sits 7.4-fold (0.87 log units) above what was measured, and the stated range ends above it.
By their numbers in this assay, from the lowest: compounds 2, 4 and 1 (each within the scatter of the next); then compound 3.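

In this assay, among the compounds shown here, the exchange at this position gives the first single-place step, a 3.9-fold lower number from compound 3 to compound 4 (0.60 log units; beyond the scatter), and it lies beyond the scatter. On this aromatic carbon, next to the ring nitrogen and ortho to the 2-fluoro-5-methoxyphenyl group, the five-membered ring of 5,5-dimethylcyclopent-1-en-1-yl is therefore not needed to keep the number low on the core of compound 3: the 2-methylprop-1-en-1-yl group, with no ring and 4 heavy atoms in place of 7, gives the lower number while keeping the 1 double bond outside aromatic rings. Nothing available accounts for the direction or size of this step, so it stands as an observation on this one pair.

The compounds shown leave open whether the same exchange lowers the number on the cores of compound 1 and compound 2, since this step is read on one core only. They also leave open whether the double bond matters at this position, which a saturated isobutyl group there would test, and whether a still smaller group such as ethyl continues the step.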